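Swapping the sulfur-linked ring of compound 2 for a phenylpiperazine

The source may hold more compounds than are shown below. What is called first, only, known or untested is meant among the compounds shown, and "the series" means these compounds.

Compound 2 `Cn1c(-c2ccc(NC(=O)CSC3=NCCS3)cc2)nc(-c2ccccc2)c1-c1ccccc1` is, within the scatter, the higher of the two measured compounds in a functional assay on HT-29 cells (Homo sapiens) for cytotoxicity, read by MTT assay, with a stated time of 24 h, tested at 80 ug/mL (a higher number here means a stronger effect of the compound at the concentration tested, a lower number a weaker effect), where compound 2 gives 75.2%. Its nearest neighbour is compound 1 `Cc1ccc2oc(SCC(=O)Nc3ccc(-c4nc(-c5ccccc5)c(-c5ccccc5)n4C)cc3)nc2c1`, which in this assay gives 69.8%; the step of a number 5.4 percentage points higher from compound 1 to compound 2 (within the scatter) shows that exchanging the group on the sulfur changed little. Compound 3 `Cn1c(-c2ccc(NC(=O)CN3CCN(c4ccccc4)CC3)cc2)nc(-c2ccccc2)c1-c1ccccc1` differs from compound 2 at a different place, on a saturated chain carbon bound to a carbonyl carbon: a group of 12 heavy atoms (10 carbon, 2 nitrogen; one six-membered non-aromatic ring with 2 hetero atoms, one six-membered aromatic ring of carbon only) in place of a group of 6 heavy atoms (3 carbon, 1 nitrogen, 2 sulfur; one five-membered non-aromatic ring with 2 hetero atoms), on a saturated chain carbon bound to a carbonyl carbon. Among the compounds with values here, no measured step touches that position, and the only step known, a number 5.4 percentage points higher from compound 1 to compound 2 (within the scatter), stayed within the scatter when the tail beyond the amide was varied, so no step beyond the scatter is expected in this assay. Compound 3 is therefore estimated to give 70%, between 50% and 85%, a step of a number 5.2 percentage points lower from compound 2 to compound 3 (within the scatter) from compound 2 that is expected to sit within the scatter.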

Compound 3, a percentage reported as activity, at one concentration (the size of the read-out at that concentration, not a potency): 63.7%
Beside the measured number, compound 3's estimate is 6.3 percentage points above it, within the range that was stated.
By their numbers in this assay, from the lowest: compounds 3, 1 and 2 (each within the scatter of the next, the first and the last beyond it).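

Within the data shown here, at the saturated chain carbon bound to a carbonyl carbon, 4-phenylpiperazin-1-yl in place of the sulfur-linked five-membered ring gives a number 11.5 percentage points lower from compound 2 to compound 3 (beyond the scatter) in this assay and is the first modest step beyond the scatter in this set. Set against (5-methyl-1,3-benzoxazol-2-yl)sulfanyl, the same group gives a number 6.1 percentage points lower from compound 1 to compound 3 (within the scatter) and so shows that the size of the change depends on which sulfur-linked group it replaces. Nothing available bears on the reason for this difference.

The compounds shown leave open whether the phenyl on the piperazine matters, which a methyl in its place would test. They also leave open whether a morpholine or a simple dimethylamino group at this carbon would give a number closer to that of compound 2 or compound 3.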